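This account rests on a few compounds, and the source may have more. Where it says the series, first, only, none or still open, it means among the compounds named here.

Measured so far:
- Compound 1 `OC[C@H]1O[C@@H](n2cnc3c(NCc4ccc(F)cc4)ncnc32)[C@H](O)[C@@H]1O` gives 2700 nM in a functional assay on K562 cells (Homo sapiens) for antiproliferative activity, with a stated time of 72 h; a higher number here means a weaker inhibitor, a lower number a stronger inhibitor.
- Compound 2 `OC[C@H]1O[C@@H](n2cnc3c(NCc4cccc(Br)c4)ncnc32)[C@H](O)[C@@H]1O` gives 19700 nM in this assay.
- Compound 3 `COc1cc(CNc2ncnc3c2ncn3[C@@H]2O[C@H](CO)[C@@H](O)[C@H]2O)cc(OC)c1` reaches only a limit, > 166000 nM, in this assay.

Compound 2 holds the highest of the two numbers shown; the nearest is compound 1, at a 7.3-fold higher number from compound 1 to compound 2 (0.86 log units; beyond the scatter). Compound 4 `OC[C@H]1O[C@@H](n2cnc3c(NCc4ccccc4OC(F)F)ncnc32)[C@H](O)[C@@H]1O` carries the change (2-(difluoromethoxy)phenyl in place of 3-bromophenyl on a saturated chain carbon bound to a nitrogen on an aromatic ring). Going by the values given here, the steps that bear on it are the other aryl swaps at the same carbon: a 7.3-fold higher number from compound 1 to compound 2 (0.86 log units; beyond the scatter), an at least 8.4-fold higher number from compound 2 to compound 3 (0.92 log units; beyond the scatter) and an at least 61-fold higher number from compound 1 to compound 3 (1.78 log units; beyond the scatter), all beyond the scatter and in either direction. Among the compounds with values here, no measured compound carries a group of this kind, so the expected step of a 1.3-fold lower number from compound 2 to compound 4 (0.12 log units; within the scatter) is set near zero with a wide range. Compound 4 is estimated at 15000 nM, between 3000 nM and 100000 nM.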

Compound 4, half-maximal inhibitory concentration: > 166000 nM
Compound 4 gave a limit, no number (the forecaster's own chance of this, stated with the estimate: 15%); middle value at least 11-fold (1.04 log units) from the limit.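

In this assay compound 4 gives a limit, not a number, so the 2-(difluoromethoxy)phenyl group ends at the same limit as the 3,5-dimethoxyphenyl group of compound 3: the limit of > 166000 nM in this assay, at which 2 of the 4 values shown sit. Against the two aryl groups that give numbers, the change reads as an at least 8.4-fold higher number from compound 2 to compound 4 (0.92 log units; beyond the scatter) and an at least 61-fold higher number from compound 1 to compound 4 (1.78 log units; beyond the scatter), so both oxygen-bearing aryl groups on this carbon now sit at the limit. The step between compound 3 and compound 4 cannot be read from two limits.

Still open, going by these compounds, is whether the oxygen link or the place of the substituent on the ring matters more. On these data alone, it is also open whether 2-methoxyphenyl, 2-fluorophenyl or an aryl group carrying an amine would return a readable number.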